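Removing a Methyl from the Aryl Ether of Compound 2

A few compounds are considered here, and "the series" means these few. Any claim that something is new, unique, unknown or untested is made for them only; others in the source may bear on it.

Measured so far:
compound 1 `CCc1cc2cc(OC)cc(C(=O)c3ccc(O)cc3)c2o1` — 60%
compound 2 `CCc1cc2c(C(=O)c3cc(Br)c(O)c(Br)c3)c(OC)ccc2o1` — 99.6%

In an assay for inhibition of solute carrier family 22 member 12 (Homo sapiens), read by scintillation counting, with a stated time of 60 min, tested at 50 uM (on this read-out higher numbers stand for more inhibition at the one concentration tested (going by the name of the read-out) and lower numbers for less inhibition), compound 2 gives the higher of the two numbers; compound 1 lies below it by a margin beyond the usual scatter. The step to compound 3 `CCc1cc2c(C(=O)c3cc(Br)c(O)c(Br)c3)c(O)ccc2o1` is small: hydrogen in place of methyl on an oxygen on an aromatic ring, which one bond further out reads methoxy to hydroxy. Going by the values given here, no measured pair shows this change, so its effect is unknown. Since compound 2 sits near the top of the read-out, the estimated step of a number 7.6 percentage points lower from compound 2 to compound 3 (within the scatter) is expected to be small and downward, if beyond the scatter at all. Compound 3 is estimated at 92%, between 70% and 100%.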

Compound 3, a percentage reported as inhibition, at one concentration (the size of the read-out at that concentration, not a potency): 99.9%
Compound 3: middle estimate off by 7.9 percentage points, on the low side, and the stated range covers the measured number.
By their numbers in this assay, from the lowest: compound 1; then compounds 2 and 3 (each within the scatter of the next).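

On this assay hydrogen in place of methyl on an oxygen on an aromatic ring gives a number 0.3 percentage points higher from compound 2 to compound 3 (within the scatter) and so shows that methoxy and hydroxy read alike at this place. Both numbers sit near the top of the read-out, so at the one concentration tested any difference between these compounds could stay hidden. Nothing available here accounts for this result. The compounds shown leave open how ethoxy, an amine or a carboxylic acid at this place would read.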